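A Methoxy Swap on the Shared Core

The source may report more compounds than this note shows. Statements on the series, on what has been measured and on what is new or still open speak of the compounds shown alone.

- compound 1 `O=C1C=CCC/C1=C\C=C\c1ccccc1` gives 7100 nM
- compound 2 `O=C1C=CCC/C1=C\C=C\c1ccc(Br)cc1` gives 6100 nM
- compound 3 `O=C1C=CCC/C1=C\C=C\c1ccccc1[N+](=O)[O-]` gives 6800 nM

In a functional assay on HepG2 cells (Homo sapiens) for cytotoxicity, read by MTT assay, with a stated time of 72 h (a higher number here means a weaker inhibitor, a lower number a stronger inhibitor), compound 3 gives 6800 nM and lies within the scatter of both compound 1 and compound 2. Compound 4 `COc1ccccc1/C=C/C=C1\CCC=CC1=O` carries methoxy in place of nitro on an aromatic carbon and has not yet been measured. For the measured compounds named here, no measured step covers methoxy itself. The nearest steps are a 1.0-fold lower number from compound 1 to compound 3 (0.02 log units; within the scatter) for nitro in place of hydrogen and a 1.2-fold lower number from compound 1 to compound 2 (0.07 log units; within the scatter) for bromo in place of hydrogen, both within the scatter. The step expected in this assay is a 1.0-fold lower number from compound 3 to compound 4 (0.02 log units; within the scatter) and is estimated to stay within the scatter. Compound 4 is expected at 6500 nM (estimated range 3500 nM to 12000 nM).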

Compound 4, half-maximal inhibitory concentration: 5800 nM
For compound 4 the middle estimate is 1.1-fold (0.05 log units) above the measured one, within the range that was stated.
By their numbers in this assay, from the lowest: compounds 4, 2, 3 and 1 (each within the scatter of the next).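

In this assay, methoxy in place of nitro on this aromatic carbon, ortho to a large group, gives a 1.2-fold lower number from compound 3 to compound 4 (0.07 log units; within the scatter), and methoxy in place of hydrogen gives a 1.2-fold lower number from compound 1 to compound 4 (0.09 log units; within the scatter). Both nitro and methoxy at this position thus stay within the scatter of the unsubstituted compound 1, though the two groups share neither size nor atom make-up. Nothing measured here offers a reason for this. From the compounds shown here alone, whether an amine or a carboxylic acid on this carbon would also stay within the scatter remains open, as does a longer chain in place of methoxy.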